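Amine aryl variation: fluoro to methoxy on compound 3

The source may report more compounds than this note shows. Statements on the series, on what has been measured and on what is new or still open speak of the compounds shown alone.

Within the series sharing the core of compound 3 `CCS(=O)(=O)Nc1cc(-c2ccc3ncnc(Nc4ccc(F)nc4)c3c2)cnc1OC`, variation of the aryl on the amine nitrogen gives compound 2 `CCS(=O)(=O)Nc1cc(-c2ccc3ncnc(Nc4cccc(C(=O)OC)c4)c3c2)cnc1OC` with 1120 nM in a functional assay on SNU-638 cells (Homo sapiens) for cytotoxicity, read by sulforhodamine B assay, with a stated time of 72 h (on this read-out lower numbers stand for stronger inhibition and higher numbers for weaker inhibition), compound 1 `CCS(=O)(=O)Nc1cc(-c2ccc3ncnc(Nc4ccc(OC)cc4)c3c2)cnc1OC` with 3970 nM, and compound 3 with 6520 nM, the highest number of the three. Compound 4 `CCS(=O)(=O)Nc1cc(-c2ccc3ncnc(Nc4ccc(OC)nc4)c3c2)cnc1OC` carries methoxy in place of fluoro on an aromatic carbon. Among the compounds with values here, no measured step changes that single substituent; the nearest comparison is a 1.6-fold higher number from compound 1 to compound 3 (0.22 log units; within the scatter), which also exchanges a methoxy-bearing aryl for the fluoro-bearing one, whereas a 3.5-fold lower number from compound 1 to compound 2 (0.55 log units; beyond the scatter) and a 5.8-fold higher number from compound 2 to compound 3 (0.77 log units; beyond the scatter) involve the ester. A step of a 1.4-fold lower number from compound 3 to compound 4 (0.16 log units; within the scatter) in this assay is therefore expected. Compound 4 is estimated at 4500 nM, with a range of 1500 nM to 13000 nM.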

Compound 4, half-maximal inhibitory concentration: 4280 nM
Compound 4: the middle estimate sits 1.1-fold (0.02 log units) above what was measured; measured number inside the range.
By their numbers in this assay, from the lowest: compound 2; then compounds 1, 4 and 3 (each within the scatter of the next).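

At the aromatic carbon next to the ring nitrogen, methoxy in place of fluoro gives no change beyond the scatter in this assay (a 1.5-fold lower number from compound 3 to compound 4 (0.18 log units; within the scatter)). The 6-methoxypyridin-3-yl and 4-methoxyphenyl groups also read alike (a 1.1-fold higher number from compound 1 to compound 4 (0.03 log units; within the scatter)), while the 3-(methoxycarbonyl)phenyl group remains clearly apart (a 3.8-fold higher number from compound 2 to compound 4 (0.58 log units; beyond the scatter)). No available evidence bears on these steps.

Still open, going by these compounds, is whether an amine or an ethoxy group at this position would shift the number beyond the scatter. Also open, on these data alone, is whether a methoxycarbonyl group would have the same effect on the pyridine ring.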